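The compounds below may be only part of what the source reports. "The series", "measured", "known", "first", "only" and "open" are said of these compounds alone.

Of the compounds shown here, two have been tested in a functional assay on the whole organism for inhibition, with Rattus norvegicus as the target; on this read-out higher numbers stand for an effect only at larger amounts of compound and lower numbers for an effect already at smaller amounts. Compound 1, with the structure `CC1CC/C(=N\Nc2ccccc2F)c2ncc(C(=O)O)c(=O)n21`, carries a fluorophenyl group on the hydrazone part of the shared core; in this assay compound 1 gives 5 umol/kg. Compound 2, with the structure `CC(=O)c1ccc(N/N=C2\CCC(C)n3c2ncc(C(=O)O)c3=O)cc1`, carries an acetyl-bearing phenyl group at the same part of the core; in this assay compound 2 gives 9.5 umol/kg. The gap between these two numbers lies within the usual scatter of repeated measurements, so the two compounds cannot be told apart on the data shown, and nothing should be read into which of them stands where.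

Compound 3, with the structure `CNC(=O)c1ccc(N/N=C2\CCC(C)n3c2ncc(C(=O)O)c3=O)cc1`, follows compound 2 with one change: methylamino in place of methyl on a carbonyl carbon. Among the measured compounds shown here, no measured pair in this set shows what such a change does, so the only guide is the narrow spread of the two numbers already known. The step from compound 2 to compound 3 is expected to be small, no change at the digits printed from compound 2 to compound 3 (within the scatter), and not beyond the scatter in either direction. Compound 3 is therefore estimated at 9.5 umol/kg in this assay, with a range from 4 umol/kg to 25 umol/kg.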

Compound 3, dose for 50% inhibition: 9.6 umol/kg
Compound 3: the middle estimate sits 1.0-fold (0.00 log units) below what was measured; low and high end bracket the measured number.
By their numbers in this assay, from the lowest: compounds 1, 2 and 3 (each within the scatter of the next).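

Among the compounds shown here, this is the first pair that differs in only one place, so a single change can be read directly for the first time: in this assay, methylamino in place of methyl on a carbonyl carbon gives a 1.0-fold higher number from compound 2 to compound 3 (0.00 log units; within the scatter). The exchange of acetyl for methylcarbamoyl adds one heavy atom, a nitrogen, and one hydrogen-bond donor, yet compound 2 and compound 3 cannot be told apart on this whole-organism read-out, so at this position the change has no effect that can be detected here. No measurement shown here offers an explanation for this result.

For the compounds shown here, a single pair covers only one exchange, so it remains open whether the same carbonyl carbon would give a similar number when carrying a longer chain such as ethylamino or a dimethylamino group. As far as these compounds go, a carboxylic acid at this place, with hydroxyl on the carbonyl carbon, is also open, as is whether methylcarbamoyl would give the same kind of step on the fluorophenyl compound 1.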